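Swapping a Chlorophenyl for a Methylphenyl in Cytotoxicity Testing

The source may report more compounds than this note shows. Statements on the series, on what has been measured and on what is new or still open speak of the compounds shown alone.

compound 1 `Cc1cc(-c2ccc(F)cc2)cc(C)c1Oc1cc(N)nc(Nc2ccc(C#N)cc2)n1`: 23100 nM
compound 2 `Cc1cc(-c2ccccc2Cl)cc(C)c1Oc1cc(N)nc(Nc2ccc(C#N)cc2)n1`: 25100 nM
compound 3 `Cc1cc(-c2cccc(Cl)c2)cc(C)c1Oc1cc(N)nc(Nc2ccc(C#N)cc2)n1`: 22300 nM

In a toxicity assay on MT4 cells (Homo sapiens) for cytotoxicity, read by MTT assay (a lower number here means that less compound is tolerated, a higher number that more compound is tolerated), compound 3 gives 22300 nM, level with the other two compounds. Its measured steps are a 1.0-fold lower number from compound 1 to compound 3 (0.02 log units; within the scatter) and a 1.1-fold lower number from compound 2 to compound 3 (0.05 log units; within the scatter), so it cannot be told apart from either.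

The next compound is compound 4 `Cc1ccccc1-c1cc(C)c(Oc2cc(N)nc(Nc3ccc(C#N)cc3)n2)c(C)c1`. The change is 2-methylphenyl in place of 3-chlorophenyl on an aromatic carbon. Put simply, this is 2-methylphenyl in place of 3-chlorophenyl on an aromatic carbon.

Within the data shown here, no measured compound carries 2-methylphenyl, so the best guide is the set of earlier exchanges of one substituted phenyl group for another at this same place. Besides the two steps above, there is a 1.1-fold higher number from compound 1 to compound 2 (0.04 log units; within the scatter). All three stayed within the scatter, so no step beyond the scatter is expected in this assay, in either direction. The expected change is a 1.0-fold higher number from compound 3 to compound 4 (0.01 log units; within the scatter). The estimate for compound 4 is 23000 nM, with an expected range from 13000 nM to 40000 nM.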

Compound 4, half-maximal cytotoxic concentration: 25600 nM
For compound 4 the middle estimate is 1.1-fold (0.05 log units) below the measured one; the measured number falls inside the stated range.
By their numbers in this assay, from the lowest: compounds 3, 1, 2 and 4 (each within the scatter of the next).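

A phenyl group carrying methyl rather than a halogen stands level with the halogen-bearing ones in this assay with a 1.1-fold higher number from compound 3 to compound 4 (0.06 log units; within the scatter) and a 1.1-fold higher number from compound 1 to compound 4 (0.04 log units; within the scatter) and a 1.0-fold higher number from compound 2 to compound 4 (0.01 log units; within the scatter) all within the scatter. The last of these steps is the closest comparison, as methyl takes the place of chloro on an otherwise identical phenyl group, and this exchange leaves the two compounds impossible to tell apart. Nothing available here explains why these compounds sit so close together.

From the compounds shown here alone, all four compounds carry a substituted phenyl group at this place, so the effect of an amine or a carboxylic acid on that phenyl group stays open. Also open, going by these compounds, is whether any change at this place can move the number in this assay beyond the scatter.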